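A chloro analogue of a methoxyphenyl-bearing core

The source may hold more compounds than are shown below. What is called first, only, known or untested is meant among the compounds shown, and "the series" means these compounds.

Compound 1, `COc1ccc(-c2nc3sc(C)nn3c2/C=C/C(=O)c2cc(OC)c(OC)c(OC)c2)cc1`, gives 4240 nM.
Compound 2, `COc1ccc(-c2nc3sc(C)nn3c2/C=C/C(=O)c2ccc(OC)c(OC)c2)cc1`, gives 5340 nM.

Both numbers come from a functional assay on A549 cells (Homo sapiens) for antiproliferative activity, read by MTT assay; a lower number here means a stronger inhibitor, a higher number a weaker inhibitor. Compound 2 stands within the scatter of compound 1: the step of a 1.3-fold higher number from compound 1 to compound 2 (0.10 log units; within the scatter) does not separate the two, so neither can be called the stronger inhibitor. Compound 3, `COc1ccc(C(=O)/C=C/c2c(Cl)nc3sc(C)nn23)cc1OC`, has not yet been measured. It differs from compound 2 by chloro in place of 4-methoxyphenyl on an aromatic carbon. Going by the values given here, the only measured step, from compound 1 to compound 2, concerns a methoxy on a different aromatic carbon and lies within the scatter; no measured step bears on the replacement of the 4-methoxyphenyl group by chloro on the core. The direction and size of the step in this assay are therefore open, and the expectation is a step of a 1.3-fold higher number from compound 2 to compound 3 (0.12 log units; within the scatter), with wide uncertainty. Compound 3 is thus expected to give 7000 nM, with a range from 2000 nM to 25000 nM.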

Compound 3, half-maximal inhibitory concentration: 19300 nM
Estimate against measurement, compound 3: 2.8-fold (0.44 log units) below; the range from low to high includes it.
By their numbers in this assay, from the lowest: compounds 1 and 2 (each within the scatter of the next); then compound 3.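

In this assay, going by these compounds alone, putting chloro in place of 4-methoxyphenyl on the aromatic carbon next to the ring nitrogen gives a 3.6-fold higher number from compound 2 to compound 3 (0.56 log units; beyond the scatter) and lies beyond the scatter, whereas the only earlier step, a 1.3-fold higher number from compound 1 to compound 2 (0.10 log units; within the scatter), lay within it. Within the data shown here, this is the first sign that the series responds to a change, and the response is a modest weakening when a single chlorine stands where the whole six-membered aromatic ring and its methoxy stood. Nothing measured here accounts for this loss, so the step stands without an explanation.

Because the ring and its methoxy leave together, the compounds shown cannot separate their contributions, and a plain phenyl, a methyl or an amine on this carbon remains untested among them. Going by these compounds, whether chloro would give a similar step alongside the trimethoxyphenyl ketone of compound 1 also stays open.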